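Ortho-methoxy on the phenyl of compound 1: an estimate

The source may hold more compounds than are shown below. What is called first, only, known or untested is meant among the compounds shown, and "the series" means these compounds.

Measured compounds:
- compound 1, `c1ccc(-c2cn3ccnc3c(-c3ccc4ncn(C5CCCCC5)c4c3)n2)cc1`: 50.5%
- compound 2, `c1ccc2c(-c3cn4ccnc4c(-c4ccc5ncn(C6CCCCC6)c5c4)n3)cccc2c1`: 4.43%
- compound 3, `Fc1ccc(-c2cn3ccnc3c(-c3ccc4ncn(C5CCCCC5)c4c3)n2)cc1`: 0.69%

In a functional assay on NCI/ADR-RES cells (Homo sapiens) for inhibition, read by sulforhodamine B assay, with a stated time of 48 h, tested at 10 uM (on this read-out lower numbers stand for less inhibition and higher numbers for more inhibition at the one concentration tested (going by the name of the read-out)), compound 1 gives 50.5%, the highest of the three numbers. The two changes made on its phenyl ring each pulled the read-out down sharply: a number 46.1 percentage points lower from compound 1 to compound 2 (beyond the scatter) and a number 49.8 percentage points lower from compound 1 to compound 3 (beyond the scatter). Between compound 2 and compound 3 the difference stays small, a number 3.7 percentage points lower from compound 2 to compound 3 (within the scatter).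

Compound 4, `COc1ccccc1-c1cn2ccnc2c(-c2ccc3ncn(C4CCCCC4)c3c2)n1`, has not yet been measured in this assay. It differs from compound 1 by methoxy in place of hydrogen on an aromatic carbon, on an aromatic carbon of a six-membered aromatic ring of carbon only, ortho to a large group.

Among the measured compounds shown here, no step on record concerns a methoxy group, so the expectation rests on the general picture: every substitution tried on this phenyl ring, whether a larger ring system as in compound 2 or a single fluoro as in compound 3, cost most of the inhibition. A methoxy group is a third such substitution, at a different position, and the same direction is expected, though with wide uncertainty. For compound 4 the expected step is a number 35.5 percentage points lower from compound 1 to compound 4 (beyond the scatter), a loss beyond the scatter. Compound 4 is therefore estimated at 15%, in the range 0% to 45%.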

Compound 4, a percentage reported as inhibition, at one concentration (the size of the read-out at that concentration, not a potency): 0.06%
Beside the measured number, compound 4's estimate is 14.9 percentage points above it; the range from low to high includes it.
By their numbers in this assay, from the lowest: compounds 4, 3 and 2 (each within the scatter of the next); then compound 1.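

The step of a number 50.4 percentage points lower from compound 1 to compound 4 (beyond the scatter) in this assay adds methoxy, at the place ortho to a large group, to the replacements on the phenyl of compound 1 that leave little of its inhibition, so the loss is not confined to fluoro or naphthalen-1-yl. The new compound also cannot be told apart from the two earlier ones: the reading goes a number 0.6 percentage points lower from compound 3 to compound 4 (within the scatter) and a number 4.4 percentage points lower from compound 2 to compound 4 (within the scatter), which puts 2-methoxyphenyl, 4-fluorophenyl and naphthalen-1-yl on one low level, with the plain phenyl of compound 1 alone standing clear of them among these four compounds. Nothing available here accounts for why each of these three replacements gives so low a reading.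

Going by these compounds, what stays open is whether any group on this ring can keep the inhibition, for instance an amine or a carboxylic acid, or a methoxy on another carbon of the ring. Since all of these readings come from a single concentration, they also leave open how the compounds would compare across a range of concentrations.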